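Trifluoromethyl in place of methoxy: working notes on the series

The source may hold more compounds than are shown below. What is called first, only, known or untested is meant among the compounds shown, and "the series" means these compounds.

compound 1 `O=C(/C=C/c1ccc(O)c(O)c1)N1CCN(c2ccc(F)cc2)CC1` gives 1.44 ug/mL
compound 2 `O=C(/C=C/c1ccc(O)c(O)c1)N1CCN(c2cccc(Cl)c2)CC1` gives 1.34 ug/mL
compound 3 `COc1cccc(N2CCN(C(=O)/C=C/c3ccc(O)c(O)c3)CC2)c1` gives 0.92 ug/mL

All three values come from a functional assay on MCF7 cells (Homo sapiens) for antiproliferative activity, read by MTT assay, with a stated time of 48 h (a lower number here means a stronger inhibitor, a higher number a weaker inhibitor), and cannot be separated. For compound 3, the two steps that reach it are a 1.6-fold lower number from compound 1 to compound 3 (0.19 log units; within the scatter) and a 1.5-fold lower number from compound 2 to compound 3 (0.16 log units; within the scatter) and neither clears the scatter.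

Among the measured compounds shown here, compound 4 `O=C(/C=C/c1ccc(O)c(O)c1)N1CCN(c2cccc(C(F)(F)F)c2)CC1` has trifluoromethyl in place of methoxy on an aromatic carbon and no measured compound carries that group. The nearest evidence is a 1.5-fold lower number from compound 2 to compound 3 (0.16 log units; within the scatter) and a 1.1-fold lower number from compound 1 to compound 2 (0.03 log units; within the scatter) and both stayed small. No step beyond the scatter is therefore expected in this assay and no direction can be called.

The estimate means a 1.3-fold higher number from compound 3 to compound 4 (0.12 log units; within the scatter) as the expected step. For compound 4 the estimated value is 1.2 ug/mL with an expected range of 0.6 ug/mL to 2.4 ug/mL for repeat measurements.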

Compound 4, half-maximal inhibitory concentration: 1.24 ug/mL
Beside the measured number, compound 4's estimate is 1.0-fold (0.01 log units) below it; the measured number falls inside the stated range.
By their numbers in this assay, from the lowest: compounds 3, 4, 2 and 1 (each within the scatter of the next).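

On this aromatic carbon, trifluoromethyl now joins chloro and methoxy in this assay, with a 1.3-fold higher number from compound 3 to compound 4 (0.13 log units; within the scatter) and a 1.1-fold lower number from compound 2 to compound 4 (0.03 log units; within the scatter). Trading methoxy, with its hydrogen-bond acceptor, for trifluoromethyl, with none, and adding heavy atoms therefore gives no resolved change across these three groups. No measurement on hand offers an explanation for this flat result. Going by these compounds, whether an amine or a carboxylic acid on this carbon would produce a step beyond the scatter remains open, as does whether trifluoromethyl on another carbon of the ring would behave alike.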